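The source may report more compounds than this note shows. Statements on the series, on what has been measured and on what is new or still open speak of the compounds shown alone.

Working notes on the series. The shared core carries a phenolic hydroxyl in compound 2 `C=C1C[C@]23C[C@@]1(O)CC[C@H]2c1ccc(O)c(C)c1[C@@H]3Cn1cc(-c2ccc(C(F)(F)F)cc2)nn1` and compound 3 `C=C1C[C@]23C[C@@]1(O)CC[C@H]2c1ccc(O)c(C)c1[C@@H]3Cn1cc(-c2ccc(Br)cc2)nn1`, and a tosylate in its place in compound 1 `C=C1C[C@]23C[C@@]1(O)CC[C@H]2c1ccc(OS(=O)(=O)c2ccc(C)cc2)c(C)c1[C@@H]3Cn1cc(-c2ccc(OC)cc2)nn1`; the three differ further in the substituent on the phenyl of the triazole arm. In a functional assay on HL-60 cells (Homo sapiens) for cytotoxicity, read by MTT assay, with a stated time of 4 days (on this read-out lower numbers stand for stronger inhibition and higher numbers for weaker inhibition), compound 2 gives 8950 nM. Compound 3 reaches only the limit of this assay, > 20000 nM. Compound 1 likewise reaches only the limit, > 20000 nM. The one measured step, an at least 2.2-fold higher number from compound 2 to compound 3 (0.34 log units; beyond the scatter), is therefore known only as a lower bound, and compound 3 stands at the upper end of the numbers shown, together with compound 1, as noted in the limit of > 20000 nM in this assay, at which 2 of the 3 values shown sit.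

Compound 4 `C=C1C[C@]23C[C@@]1(O)CC[C@H]2c1ccc(O)c(C)c1[C@@H]3Cn1cc(-c2ccc(OC)cc2)nn1` follows from compound 3 by methoxy in place of bromo on an aromatic carbon. Within the data shown here, no measured step in this assay bears directly on a methoxy for bromo exchange; the step from trifluoromethyl to bromo moved the number to the limit, and compound 1, which carries the same 4-methoxyphenyl, also sits at the limit. Compound 4 is therefore expected to stay near the limit, with an estimated 25000 nM (range 8000 nM to 80000 nM), which means an expected step that the limit leaves unreadable from compound 3 to compound 4.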

Compound 4, half-maximal inhibitory concentration: > 20000 nM
Compound 4 ended at the assay's limit (the forecaster's own chance of this, stated with the estimate: 65%); the middle value lies beyond the limit too.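

Methoxy in place of trifluoromethyl on this aromatic carbon gives an at least 2.2-fold higher number from compound 2 to compound 4 (0.34 log units; beyond the scatter), the same lower bound that bromo gave, so among compound 2, compound 3 and compound 4 only the trifluoromethyl group yields a readable number. The steps to compound 4 from compound 3 and from compound 1 cannot be read, because both ends of each sit at the same limit: the limit of > 20000 nM in this assay, at which 3 of the 4 values shown sit.

With the 4-methoxyphenyl group in place, compound 4 also shows that a free phenolic hydroxyl instead of the tosylate of compound 1 brings no readable number in this assay.

On these data alone, it remains open how far beyond the limit compound 1, compound 3 and compound 4 lie, so no order can be given among them, and bromo and methoxy cannot be told apart at this position. Also open, as far as these compounds go, is whether another group on this aromatic carbon, such as an amine, a carboxylic acid or a nitrile, would give a lower number than compound 2 at 8950 nM.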